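A few compounds are considered here, and "the series" means these few. Any claim that something is new, unique, unknown or untested is made for them only; others in the source may bear on it.

Working notes on the series. The shared core carries a benzamidine end and a thiophene linked to a second aromatic ring; the entries differ in the substituents on those rings. Compound 1 `N=C(N)c1ccc(-c2ccc(-c3cc(Cl)cc(Cl)c3)s2)cc1` is recorded as "not determined" (no result reported) in a functional assay on UO-31 cells (Homo sapiens) for inhibition, read by sulforhodamine B assay, with a stated time of 48 h (a higher number here means a weaker inhibitor of growth, a lower number a stronger inhibitor of growth), with no result reported. Compound 2 `N=C(N)c1ccc(-c2ccc(-c3ccc(F)cc3)s2)cc1` gives 1580 nM in this assay. Compound 3 `N=C(N)c1ccc(-c2ccc(-c3ccc(Cl)cc3)s2)cc1F` gives 1720 nM in this assay; the values of compound 2 and compound 3 lie within the usual scatter of each other, so nothing separates them on the numbers shown. Compound 4 `COc1ccc(-c2ccc(-c3ccc(C(=N)N)c(F)c3)s2)cc1` is not yet measured in this assay. Relative to compound 3, compound 4 shows the change (methoxy in place of chloro on an aromatic carbon). Among the measured compounds shown here, no measured pair in the set shows this exchange, so its effect in this assay is not known from the data; the two measured numbers sit close together and give no pointer toward either direction. The expectation is a step from compound 3 to compound 4 of a 1.2-fold higher number from compound 3 to compound 4 (0.07 log units; within the scatter), that is, none beyond the scatter. Compound 4 is therefore estimated at 2000 nM in this assay, with a range from 800 nM to 5000 nM.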

Compound 4, concentration for 50% growth inhibition: 3170 nM
Beside the measured number, compound 4's estimate is 1.6-fold (0.20 log units) below it, within the range that was stated.
By their numbers in this assay, from the lowest: compounds 2, 3 and 4 (each within the scatter of the next).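

In this assay, among the compounds shown here, the first measured pair for this exchange gives a 1.8-fold higher number from compound 3 to compound 4 (0.27 log units; within the scatter) for methoxy in place of chloro on an aromatic carbon, para to a large group. At this position, then, going from one heavy atom to two and adding a hydrogen-bond acceptor does not separate the two compounds on the numbers, though this rests on a single pair. No measured property of these groups accompanies the result, and no explanation can be attached to it.

On these data alone, whether an amine, a hydroxyl group or a longer chain such as ethoxy at this position would also stay within the scatter of compound 3 remains open. No pair shown differs only in the fluorine shared by compound 3 and compound 4, so the effect of that fluorine cannot be read.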